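A few compounds are considered here, and "the series" means these few. Any claim that something is new, unique, unknown or untested is made for them only; others in the source may bear on it.

In a functional assay on NIH3T3 cells (Mus musculus) for inhibition, read by MTT assay, with a stated time of 72 h (on this read-out higher numbers stand for weaker inhibition and lower numbers for stronger inhibition), three compounds sharing one core have been measured. Compound 1 (`C=C1CC[C@H]2[C@@](C)(CC[C@@H](OC(C)=O)[C@@]2(C)C(=O)OC)[C@@H]1CCC1=CCOC1=O`) gives 80600 nM, compound 2 (`C=C1CC[C@H]2[C@@](C)(CC[C@@H](OC(C)=O)[C@@]2(C)C(=O)OC)[C@@H]1/C=C/C1=CCOC1=O`) gives 32300 nM, and compound 3 (`C=C1CC[C@H]2[C@@](C)(CC[C@@H](O)[C@@]2(C)C(=O)OC)[C@@H]1/C=C/C1=CCOC1=O`) gives 111000 nM. Compound 2 thus has the lowest number of the three, and on this read-out a lower number means stronger inhibition.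

Compound 4 (`C=C1CC[C@H]2[C@@](C)(CC[C@@H](OC(C)=O)[C@@]2(C)C(=O)OC)[C@@H]1C/C=C1\C=COC1=O`) has not yet been measured. It has the same atoms as compound 2, joined differently: a group of 8 heavy atoms (6 carbon, 2 oxygen; one five-membered non-aromatic ring with 1 hetero atom) in place of a group of 8 heavy atoms (6 carbon, 2 oxygen; one five-membered non-aromatic ring with 1 hetero atom), on a saturated ring carbon. The change lies on a saturated ring carbon of a six-membered non-aromatic ring of carbon only.

The closest evidence is a 2.5-fold lower number from compound 1 to compound 2 (0.40 log units; beyond the scatter), where the group at that same place also changes. A change in another part of the molecule, hydrogen in place of acetyl on an oxygen, gave a 3.4-fold higher number from compound 2 to compound 3 (0.54 log units; beyond the scatter), but compound 4 keeps that acetyl. Both steps are modest, and neither shows which way the new arrangement will go. In this assay, a modest step in either direction is therefore possible, and no step beyond the scatter is the best single expectation. The expected central step is a 1.2-fold higher number from compound 2 to compound 4 (0.09 log units; within the scatter). Compound 4 is estimated at 40000 nM, with an expected range from 14000 nM to 110000 nM.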

Compound 4, half-maximal inhibitory concentration: 69700 nM
For compound 4 the middle estimate is 1.7-fold (0.24 log units) below the measured one; measured number inside the range.
By their numbers in this assay, from the lowest: compound 2; then compounds 4, 1 and 3 (each within the scatter of the next).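

In this assay the rearrangement at this saturated ring carbon gives a 2.2-fold higher number from compound 2 to compound 4 (0.33 log units; beyond the scatter) with no atom gained or lost, so the way the atoms are joined matters here, not only which atoms are present. Compound 2 therefore keeps the lowest number, and its steps to each of the other compounds lie beyond the scatter. Among these compounds, the groups of compound 4 and compound 1 cannot be told apart, with a 1.2-fold lower number from compound 1 to compound 4 (0.06 log units; within the scatter) and so, of the three arrangements at this place, only the one in compound 2 stands apart from the others. Nothing available explains why these differently joined atoms give different numbers.

The compounds shown leave open whether an amine or a carboxylic acid on the chain at this ring carbon, or a longer chain leading to the five-membered ring, would give a lower number than compound 2 does. They also leave open whether replacing the acetyl with hydrogen on the core of compound 4 would raise the number as it does for compound 2.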